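Replacing a methylphenyl with a chlorophenyl on the ether of compound 1

A few compounds are considered here, and "the series" means these few. Any claim that something is new, unique, unknown or untested is made for them only; others in the source may bear on it.

Compound 1 `Cc1cccc(OC[C@@H]2[C@H]3CC[C@H](c4nc(C(=O)O)cs4)O[C@H]3C[C@H]2O)c1` is the reference point of this account. Among the measured compounds shown here, in a functional assay on CHO cells for agonist activity at prostaglandin E2 receptor EP2 subtype (Homo sapiens), read by HTRF and cAMP accumulation, with a stated time of 30 min (on this read-out lower numbers stand for an effect already at smaller amounts and higher numbers for an effect only at larger amounts of compound), compound 1 gives 3.6 nM, the lowest of the two numbers measured so far. For the measured compounds named here, the only other measured compound, compound 2 `O=C(O)CCC[C@H]1CC[C@@H]2[C@@H](/C=C/[C@@H](O)COc3ccccc3)[C@H](O)C[C@@H]2O1`, gives 8900 nM in this assay, a far higher number that lies beyond the usual scatter; no single-point step connects it to compound 1, so its value serves only as a distant comparison.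

Compound 3 `O=C(O)c1csc([C@H]2CC[C@@H]3[C@@H](COc4ccccc4Cl)[C@H](O)C[C@@H]3O2)n1` has not yet been measured. It differs from compound 1 in one place: 2-chlorophenyl in place of 3-methylphenyl on an oxygen on a saturated carbon. The shared core, the hydroxyl and the acid-bearing ring all remain unchanged.

Because compound 1 gives 3.6 nM in this assay, a step of at most modest size is expected a 1.7-fold higher number from compound 1 to compound 3 (0.22 log units; within the scatter), with no change beyond the scatter the most likely outcome. Compound 3 is therefore estimated at 6 nM, within a range from 1.5 nM to 30 nM.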

Compound 3, half-maximal effective concentration: 3.3 nM
Estimate against measurement, compound 3: 1.8-fold (0.26 log units) above; low and high end bracket the measured number.
By their numbers in this assay, from the lowest: compounds 3 and 1 (each within the scatter of the next); then compound 2.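

In this assay, 2-chlorophenyl in place of 3-methylphenyl on an oxygen on a saturated carbon gives a step within the scatter (a 1.1-fold lower number from compound 1 to compound 3 (0.04 log units; within the scatter)), so compound 1 and compound 3 cannot be told apart. This is the first single-place step among the compounds shown, and it shows that this position can carry either of these two substituted phenyl groups with no difference beyond the scatter. Nothing measured here bears on why the two values agree.

The compounds shown leave open what the unsubstituted phenyl, 3-chlorophenyl or 2-methylphenyl would give, since this one step changes both the substituent and its place on the ring. They also leave open whether a group of another kind here, such as an amine or a pyridine ring, would be tolerated as well.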